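Swapping tert-butyl for methyl on compound 3

The source may report more compounds than this note shows. Statements on the series, on what has been measured and on what is new or still open speak of the compounds shown alone.

Compound 1 `C=CC/N=C1\S/C(=C\c2ccc(OC)cc2)C(=O)N1C` gives > 100000 nM as a limit
Compound 2 `C=C1CN/C(=N/c2ccccc2)S1` gives > 100000 nM as a limit
Compound 3 `COc1ccc(/C=C2/CN(C)/C(=N/c3ccc(C(C)(C)C)cc3)S2)cc1` gives 28700 nM as a number

These three compounds were tested in a functional assay on MCF7 cells (Homo sapiens) for antiproliferative activity, read by MTT assay, with a stated time of 72 h (on this read-out higher numbers stand for weaker inhibition and lower numbers for stronger inhibition), to see how strongly each one holds back the growth of cancer cells. Compound 3 gives 28700 nM in this assay and is the only one of the three with an actual number. The results for compound 1 and compound 2 are limits, so they cannot be placed on a scale with it.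

Compound 4 `COc1ccc(/C=C2/CN(C)/C(=N/c3ccc(C)cc3)S2)cc1` is compound 3 with a single change, methyl in place of tert-butyl on an aromatic carbon, and the rest of the structure stays the same. Within the data shown here, no pair of measured compounds here shows what a change of this kind does, so any forecast rests on very little. The expected 1.6-fold higher number from compound 3 to compound 4 (0.20 log units; within the scatter) in this assay is a modest one toward weaker inhibition, although a result within the usual scatter is also possible. Compound 3 at 28700 nM leaves little room for a much weaker reading. Compound 4 may therefore be reported only as a limit. For compound 4 the estimated value is 45000 nM with an expected range from 15000 nM to 100000 nM in this test.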

Compound 4, half-maximal inhibitory concentration: 7600 nM
Compound 4: middle estimate off by 5.9-fold (0.77 log units), on the high side, and the stated range ends above it.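

In this assay, putting methyl in place of tert-butyl on this aromatic carbon gives a 3.8-fold lower number from compound 3 to compound 4 (0.58 log units; beyond the scatter), so in this pair methyl goes with stronger inhibition than tert-butyl. Among these compounds, this is the first step in the set between two compounds that differ in one place, and it shows that what sits on this carbon can move the result by more than ordinary repeat-to-repeat variation. Both compounds give actual numbers rather than limits, which means the size of this step can be read directly, something the other two compounds do not allow: the limit of > 100000 nM in this assay, at which 2 of the 4 values shown sit.

With only tert-butyl and methyl compared at this place, a single step cannot tell which difference between the two groups lies behind the result, or whether it would hold on a different core. An ethyl group, a chlorine atom or an amine on the same aromatic carbon would show whether the reading keeps moving in this direction or whether methyl is a special case.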